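Naphthyloxyacetyl hydrazones: dropping a hydroxy from compound 2

The compounds below may be only part of what the source reports. "The series", "measured", "known", "first", "only" and "open" are said of these compounds alone.

Three members of the series have a number in a physicochemical assay for lipophilicity, measured as octanol-water partition (on this read-out higher numbers stand for higher lipophilicity and lower numbers for lower lipophilicity), so far. Compound 1 `COc1cc(/C=N/NC(=O)COc2cccc3ccccc23)cc(OC)c1OC` gives 3.26. Compound 2 `C/C(=N\NC(=O)COc1cccc2ccccc12)c1ccc(O)cc1O` gives 4.31. Compound 3 `O=C(COc1cccc2ccccc12)N/N=C/c1ccccc1Cl` gives 4.54. Compound 2 stands second highest of the three readings. The reading of compound 3 lies close to that of compound 2, within the usual scatter of this assay, so no order between the two can be claimed. The reading of compound 1 lies lower than that of compound 2 by an amount beyond the scatter. For the measured compounds named here, none of these three pairs differs in a single place, so no step between measured compounds is available; the comparison rests on the bare values.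

The next compound to be measured is compound 4 `C/C(=N\NC(=O)COc1cccc2ccccc12)c1ccccc1O`. It differs from compound 2 in one place, (hydrogen in place of hydroxy on an aromatic carbon), that is, hydrogen in place of hydroxy on an aromatic carbon. Going by the values given here, no measured pair shows this change, so its size has to be estimated rather than read off.

For compound 4 the expected reading in this assay is 4.8, with a range from 4.4 to 5.2. The expected step of a number 0.49 log units higher from compound 2 to compound 4 (beyond the scatter) is upward and somewhat beyond the scatter.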

Compound 4, partition coefficient: 3.08
For compound 4 the middle estimate is 1.72 log units above the measured one; the whole stated range lies above it.
By their numbers in this assay, from the lowest: compounds 4 and 1 (each within the scatter of the next); then compounds 2 and 3 (each within the scatter of the next).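

In this assay, for the compounds shown here, the change from 2,4-dihydroxyphenyl to 2-hydroxyphenyl gives a number 1.23 log units lower from compound 2 to compound 4 (beyond the scatter) and is the first single-place step, so the effect of this change now rests on a matched pair and not on bare values. At this position, on an aromatic carbon meta to a hydroxy group and para to a large group, hydrogen in place of hydroxy lowers the number by a large amount, even though the change removes one hydrogen-bond donor and one hydrogen-bond acceptor. Going by these compounds alone, nothing measured so far accounts for the direction or the size of this step.

The compounds shown leave open whether another group at this position, such as methoxy, chlorine or an amine, would read closer to hydroxy or to hydrogen. They also leave open whether hydrogen in place of the remaining hydroxy of the 2-hydroxyphenyl group would give a step of the same direction and size.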